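This account rests on a few compounds, and the source may have more. Where it says the series, first, only, none or still open, it means among the compounds named here.

In a functional assay on CHO cells for agonist activity at adenosine receptor A1 (Homo sapiens), read by fluorescence and ERK phosphorylation, with stated times of 30 min and 1.5 h, tested at 3 uM (on this read-out lower numbers stand for a weaker effect and higher numbers for a stronger effect at the one concentration tested), compound 3 `Nc1scc(-c2cccc(F)c2)c1C(=O)c1ccc(Cl)cc1` gives 76%, the highest of the three numbers shown. Compound 2 `Nc1scc(-c2cccc(C(F)(F)F)c2)c1C(=O)c1ccc(Cl)cc1` gives 64%, and compound 1 `Nc1scc(-c2ccc(Cl)cc2)c1C(=O)c1ccccc1` gives 46%, both beyond the scatter below compound 3. Among the compounds with values here, the only measured step is a number 12 percentage points higher from compound 2 to compound 3 (beyond the scatter), a swap of one substituent for another on the same aromatic carbon. Compound 4 `Nc1scc(-c2ccc(I)cc2)c1C(=O)c1ccc(Cl)cc1` differs from compound 3 by 4-iodophenyl in place of 3-fluorophenyl on an aromatic carbon. Within the data shown here, no measured step exchanges these two groups, and compound 1 differs from compound 3 in two places, so it offers no single-site comparison. Given this thin footing, a modest decrease is expected, a number 16 percentage points lower from compound 3 to compound 4 (beyond the scatter). Compound 4 is therefore estimated at 60%, with a range from 35% to 85%.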

Compound 4, a percentage reported as activity, at one concentration (the size of the read-out at that concentration, not a potency): 54%
Compound 4: middle estimate off by 6 percentage points, on the high side; the measured number falls inside the stated range.
By their numbers in this assay, from the lowest: compounds 1, 4 and 2 (each within the scatter of the next, the first and the last beyond it); then compound 3.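

On the aromatic carbon two ring bonds from the ring sulfur, replacing 3-fluorophenyl with 4-iodophenyl in this assay gives a number 22 percentage points lower from compound 3 to compound 4 (beyond the scatter), so this exchange of the whole aryl group weakens the effect at the one concentration tested. Unlike the earlier step, this one changes both the halogen and its place on the phenyl ring, and the drop cannot be assigned to either. Nothing shown here explains the drop.

Going by these compounds, what 3-iodophenyl or 4-fluorophenyl would give remains open, and either could help separate the two changes. Also open, on these data alone, is how a phenyl bearing an amine or a carboxylic acid would behave at this position.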